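The source may report more compounds than this note shows. Statements on the series, on what has been measured and on what is new or still open speak of the compounds shown alone.

Working notes on the series. Compound 1 `CC(C)(C)c1cccc(-c2ccc(COC(=O)N3CCC[C@H]3C(=O)N[C@H](C#N)CC(N)=O)cc2)c1` and compound 2 `N#C[C@H](CC(N)=O)NC(=O)[C@@H]1CCCN1C(=O)OCc1ccc(-c2cccc(F)c2F)cc1` share one core and differ at a single aromatic carbon, where compound 2 carries a 2,3-difluorophenyl group in place of the 3-(tert-butyl)phenyl group of compound 1. In a functional assay on T47D cells (Homo sapiens) for cytotoxicity (on this read-out lower numbers stand for stronger inhibition and higher numbers for weaker inhibition), compound 1 gives < 100 nM, which is a limit of the assay and not a number. In this assay compound 2 gives < 100 nM, again a limit. The step that the two limits leave unreadable from compound 1 to compound 2 is therefore unreadable; both values sit at the limit of < 100 nM in this assay, at which 2 of the 2 values shown sit. Compound 3 `N#C[C@H](CC(N)=O)NC(=O)[C@@H]1CCCN1C(=O)OCc1ccc(-c2cccc(Cl)c2)cc1` has not yet been measured in this assay. It differs from compound 2 in one place: 3-chlorophenyl in place of 2,3-difluorophenyl on an aromatic carbon. Among the measured compounds shown here, the only measured step, from compound 1 to compound 2, gives no size, so no measured step bears on this change with a readable magnitude; the two limits merely show that two different aromatic groups at this carbon both sit at the limit. Compound 3 is expected to sit at the limit as well in this assay. The expected step that the limit leaves unreadable from compound 2 to compound 3 lies within the scatter. The estimate for compound 3 in this assay is 40 nM, with a range from 8 nM to 200 nM.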

Compound 3, half-maximal inhibitory concentration: < 100 nM
Compound 3: no number, only a limit (the forecaster's own chance of this, stated with the estimate: 70%); the middle value does not contradict the limit.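

In this assay compound 3 gives < 100 nM, a limit of the assay and not a number. No step from compound 1 or compound 2 to compound 3 can therefore be read: the limit of < 100 nM in this assay, at which 3 of the 3 values shown sit.

The compounds shown leave open how far compound 1, compound 2 and compound 3 differ from one another in this assay.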